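The compounds below may be only part of what the source reports. "The series", "measured", "known", "first", "only" and "open" are said of these compounds alone.

Values in a physicochemical assay for solubility, in phosphate buffer, measured as kinetic solubility, at pH 7.4; a higher number here means a more soluble compound, a lower number a less soluble compound:
- Compound 1 `Cc1oc(-c2ccccc2Cl)nc1CN1CCC(C(=O)NCCCN2C[C@H](C)C[C@H](C)C2)CC1`: > 72 ug/mL, a limit.
- Compound 2 `Cc1ccccc1-c1nc(CN2CCC(C(=O)NCCCN3CCCCC3)CC2)c(C)o1`: > 65 ug/mL, a limit.
- Compound 3 `Cc1ccccc1-c1nc(CN2CCC(C(=O)NCCCN3CCCC(C(C)C)C3)CC2)c(C)o1`: > 71 ug/mL, a limit.

None of the three values is an exact number. Compound 1 stands at the limit of > 72 ug/mL in this assay, at which 1 of the 3 values shown sits.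

Compound 4 `Cc1oc(-c2c(Br)cccc2Br)nc1CN1CCC(C(=O)NCCCN2C[C@H](C)C[C@H](C)C2)CC1` differs from compound 1 in one place: 2,6-dibromophenyl in place of 2-chlorophenyl on an aromatic carbon. This puts 2,6-dibromophenyl in place of 2-chlorophenyl on an aromatic carbon.

Among the compounds with values here, the only measured step is a step that the two limits leave unreadable from compound 2 to compound 3. Within the data shown here, it is a different structural change and its size cannot be read, so no measured step gives a size for this one.

The expectation starts from compound 1 at > 72 ug/mL, which is a limit. A small step downward in this assay is expected, held loosely, and compound 4 may also return only a limit. The expected change is an at least 1.2-fold lower number from compound 1 to compound 4 (0.07 log units; that floor lies within the scatter). The estimate for compound 4 is 60 ug/mL. The expected range for compound 4 runs from 25 ug/mL to 95 ug/mL.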

Compound 4, solubility: 62.4 ug/mL
Compound 4: middle estimate off by 1.0-fold (0.02 log units), on the low side, within the range that was stated.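

In this assay, compound 4 gives the only exact number among the compounds shown, 62.4 ug/mL. At this aromatic carbon, next to the ring nitrogen and the ring oxygen, 2,6-dibromophenyl in place of 2-chlorophenyl gives an at least 1.1-fold lower number from compound 1 to compound 4 (0.06 log units; that floor lies within the scatter), so only a floor for the change is known, and that floor does not establish a real difference. The other end of this step is a limit, not a number: the limit of > 72 ug/mL in this assay, at which 1 of the 4 values shown sits.

On these data alone, the full size of this step remains open, and the step from compound 2 to compound 3 cannot be read either. Also open, as far as these compounds go, is how 2,6-dichlorophenyl, or a phenyl bearing a carboxylic acid, would read at this carbon in this assay.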